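Swapping 3-chlorophenyl for 4-chlorophenyl

The compounds below may be only part of what the source reports. "The series", "measured", "known", "first", "only" and "open" are said of these compounds alone.

Measured in a functional assay on A549 cells (Homo sapiens) for antiproliferative activity, read by MTT assay, with a stated time of 48 h; on this read-out lower numbers stand for stronger inhibition and higher numbers for weaker inhibition:
- Compound 1 `O=C(/C=C/c1ccc(/C=C/C(=O)c2ccc3ccccc3c2)o1)NO`: 29400 nM
- Compound 2 `COc1cc(/C=C/c2ccc(C(=O)NO)o2)ccc1OCc1ccccc1`: 50300 nM
- Compound 3 `O=C(/C=C/c1ccc(/C=C/C(=O)c2cccc(Cl)c2)o1)NO`: 18900 nM

Compound 3 and compound 1 lie within the usual scatter of each other, so these two cannot be ranked. Compound 2 has a number beyond the scatter above that of compound 3, which means weaker inhibition.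

The unmeasured compound 4 `O=C(/C=C/c1ccc(/C=C/C(=O)c2ccc(Cl)cc2)o1)NO` carries 4-chlorophenyl in place of 3-chlorophenyl on a carbonyl carbon. The same atoms are simply joined differently. Among the measured compounds shown here, no two measured compounds differ in one place only, so the data offer no direct guide to this change. Still, compound 3 at 18900 nM and compound 1 at 29400 nM differ in the group on that carbonyl carbon and remain within the scatter. In this assay, a step no larger than the scatter is therefore expected, with no favoured direction. The estimated step is a 1.1-fold higher number from compound 3 to compound 4 (0.02 log units; within the scatter). The expected value for compound 4 is 20000 nM, within an estimated range of 10000 nM to 40000 nM.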

Compound 4, half-maximal inhibitory concentration: 98100 nM
Compound 4: middle estimate off by 4.9-fold (0.69 log units), on the low side; measured number outside the range, above it.
By their numbers in this assay, from the lowest: compounds 3, 1, 2 and 4 (each within the scatter of the next, the first and the last beyond it).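

In this assay, 4-chlorophenyl in place of 3-chlorophenyl on the carbonyl carbon gives a 5.2-fold higher number from compound 3 to compound 4 (0.72 log units; beyond the scatter), so inhibition at this position depends on how the chlorine is attached to the ring, even though the group entering has the same atoms and the same counts as the group leaving. Among the compounds shown here, this is the first pair that differs in one place only, and it gives a direct reading of a change here: weaker inhibition with 4-chlorophenyl. No measurement shown gives a reason for this step.

The compounds shown leave open how a plain phenyl or a pyridine ring on the same carbonyl carbon would compare with compound 3. They therefore also leave open whether the chlorine itself matters here, or only its place on the ring.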